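Pyridin-2-yl Gives Way to Benzofuran on the Sulfonyl

The compounds below may be only part of what the source reports. "The series", "measured", "known", "first", "only" and "open" are said of these compounds alone.

Compound 1 `CCN(Cc1ccccc1)C(=O)C1CCN(S(=O)(=O)c2cccc3c2OCCO3)CC1`: 53%
Compound 2 `CCN(Cc1ccccc1)C(=O)C1CCN(S(=O)(=O)c2ccccn2)CC1`: "not determined" (no result reported)

In a functional assay on CHO cells for positive allosteric modulation of muscarinic acetylcholine receptor M5 (Homo sapiens), read by calcium flux (a higher number here means a larger maximal response, a lower number a smaller maximal response), compound 1 gives 53%. Compound 2 stands without a number in this assay, so nothing can be said of where it sits against compound 1. The step to compound 3 `CCN(Cc1ccccc1)C(=O)C1CCN(S(=O)(=O)c2ccc3occc3c2)CC1` is 1-benzofuran-5-yl in place of pyridin-2-yl on a sulfonyl sulfur. Among the compounds with values here, with no measured step to lean on, only the value of compound 1 offers an anchor, and a response of that order, or a modest shift either way beyond the scatter, is expected for compound 3. Compound 3 is therefore estimated at 55% in this assay, within 30% to 85%.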

Compound 3, largest response reached (reported as percent of maximum), in percent of the reference or control that the assay uses: 80%
Compound 3: middle estimate off by 25 percentage points, on the low side; measured number inside the range.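

In this assay, the sulfonyl sulfur gives its first readable step: with 1-benzofuran-5-yl in place of 2,3-dihydro-1,4-benzodioxin-5-yl, the result is a number 27 percentage points higher from compound 1 to compound 3 (beyond the scatter). This shows that the response at this position depends on which fused aromatic group the sulfur carries. The step involving pyridin-2-yl cannot be read, as compound 2 has no number, and nothing given here explains the rise. Still open, as far as these compounds go, is how a plain phenyl or a 1-benzothiophen-5-yl would fare on the sulfonyl sulfur. Also open, from the compounds shown here alone, is whether an amine or a carboxylic acid there would keep this response.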